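The source may hold more compounds than are shown below. What is called first, only, known or untested is meant among the compounds shown, and "the series" means these compounds.

Measured so far in a functional assay on CCRF-CEM cells for antagonist activity at C-X-C chemokine receptor type 4 (Homo sapiens), read by calcium flux, with stated times of 25 min and 90 s; a lower number here means a stronger inhibitor, a higher number a weaker inhibitor:
- compound 1 `C/C(CN)=C(\F)CN(C[C@H]1Cc2ccccc2CN1)[C@H]1CCCc2cccnc21`: 28 nM
- compound 2 `NC[C@H]1CC[C@H](CN(C[C@H]2Cc3ccccc3CN2)[C@H]2CCCc3cccnc32)CC1`: 340 nM

For the measured compounds named here, compound 2 has the higher of the two numbers in this assay; its only neighbour is compound 1, and the step of a 12-fold higher number from compound 1 to compound 2 (1.08 log units; beyond the scatter) is the one comparison available.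

Compound 3 `N[C@H]1CC[C@@H](N(C[C@H]2Cc3ccccc3CN2)[C@H]2CCCc3cccnc32)CC1` is not yet measured. It differs from compound 2 in one place: 4-aminocyclohexyl in place of (4-(aminomethyl)cyclohexyl)methyl on an amine nitrogen. Both the ring-bearing chain on the amine nitrogen and the chain carrying the terminal amine are shortened at once, while the ring itself, its donor and acceptor count and the two stereocentres are kept.

Going by the values given here, no measured step covers this kind of shortening. Among the compounds with values here, the one step known, a 12-fold higher number from compound 1 to compound 2 (1.08 log units; beyond the scatter), swapped an open fluoroalkenyl chain for the cyclohexyl-bearing chain and gave a large rise; it says nothing direct about pulling the ring and the amine closer to the nitrogen. The expectation for compound 3 is therefore a step of uncertain direction, around a 1.3-fold higher number from compound 2 to compound 3 (0.12 log units; within the scatter), most likely not far beyond the scatter. For compound 3 the estimated value in this assay is 450 nM, with a range from 140 nM to 1400 nM.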

Compound 3, half-maximal inhibitory concentration: 1800 nM
Beside the measured number, compound 3's estimate is 4.0-fold (0.60 log units) below it; the measured number lies above the stated range.
By their numbers in this assay, from the lowest: compound 1; then compound 2; then compound 3.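

In this assay the change on the amine nitrogen from (4-(aminomethyl)cyclohexyl)methyl to 4-aminocyclohexyl gives a 5.3-fold higher number from compound 2 to compound 3 (0.72 log units; beyond the scatter) and so shows that this position responds to the shortening, even with the six-membered carbon ring and the hydrogen-bond donor, acceptor and stereocentre counts unchanged. Replacing the 3-(aminomethyl)-2-fluorobut-2-en-1-yl group with 4-aminocyclohexyl on the same nitrogen gives a 64-fold higher number from compound 1 to compound 3 (1.81 log units; beyond the scatter) and widens the spread of the series, with both cyclohexyl-bearing compounds now weaker inhibitors than compound 1, a pattern that extends only to these three compounds. No measurement shown accounts for the loss on shortening.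

Compound 3 shortens the link to the ring and the link from the ring to the terminal amine together, so the two changes cannot be told apart; a (4-aminocyclohexyl)methyl group on the amine nitrogen would separate them. Also open, on these data alone, is how a saturated 4-aminobutyl chain at this position would compare with the fluoroalkenyl chain of compound 1.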